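A Fluoro Substituent on Two Different Rings in Receptor Binding

The source may hold more compounds than are shown below. What is called first, only, known or untested is meant among the compounds shown, and "the series" means these compounds.

Three compounds have been measured in an assay on isolated protein for binding affinity to melanin-concentrating hormone receptor 1 (Homo sapiens); on this read-out higher numbers stand for weaker inhibition and lower numbers for stronger inhibition:
compound 1 `COc1cc(OC)cc(C(=O)NC2CCN(Cc3ccc4ccccc4c3)CC2)c1` with 27 nM
compound 2 `COc1cc(OC)cc(C(=O)NC2CCN(Cc3ccc4cc(F)ccc4c3)CC2)c1` with 32 nM
compound 3 `COc1cccc(C(=O)N[C@@H]2CCN(Cc3ccc4ccccc4c3)C2)c1` with 67 nM

Compound 2 differs from compound 1 by fluoro in place of hydrogen on an aromatic carbon, a change that made a 1.2-fold higher number from compound 1 to compound 2 (0.07 log units; within the scatter). Compound 3 has a different core, and the difference between the two cores is not broken down here; its number stands beyond the scatter from both compound 1 and compound 2.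

Compound 4 `COc1cc(C(=O)N[C@@H]2CCN(Cc3ccc4ccccc4c3)C2)ccc1F` differs from compound 3 by fluoro in place of hydrogen on an aromatic carbon. This is the same kind of change as from compound 1 to compound 2, but its place differs: there the fluoro entered a ring that is part of a fused or bridged system of two rings, meta and para to a fused ring; here it enters a ring ortho to a methoxy group and para to a large group. Resting on the step of a 1.2-fold higher number from compound 1 to compound 2 (0.07 log units; within the scatter) in this assay, the step to compound 4 is expected to be a 1.0-fold higher number from compound 3 to compound 4 (0.02 log units; within the scatter). Compound 4 is therefore estimated at 70 nM, between 35 nM and 140 nM.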

Compound 4, inhibition constant: 62 nM
Compound 4: the middle estimate sits 1.1-fold (0.05 log units) above what was measured; the measured number falls inside the stated range.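

In this assay, fluoro in place of hydrogen on an aromatic carbon gave a 1.1-fold lower number from compound 3 to compound 4 (0.03 log units; within the scatter), and set beside the same change on the other core, the two steps do not differ: the same change on two cores in this assay, a 1.2-fold higher number (0.07 log units; within the scatter) from compound 1 to compound 2 and a 1.1-fold lower number (0.03 log units; within the scatter) from compound 3 to compound 4, 1.3-fold (0.11 log units) apart, within the scatter of two such steps. Across these two cores, then, the change carried over with no step beyond the scatter, even though the fluoro entered a different ring in each. This rests on one pair per core, however, and it does not show how the change would behave at another place or on a further core.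

The compounds shown leave open whether chloro, methyl or trifluoromethyl in place of the fluoro would give a step beyond the scatter. They also leave open what an amine or a carboxylic acid would do at the place ortho to a methoxy group.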